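Cyclopropyl for propyl beside the amide nitrogen

This account rests on a few compounds, and the source may have more. Where it says the series, first, only, none or still open, it means among the compounds named here.

Measured compounds:
compound 1 `CCC[C@@H](NC(=O)c1nccs1)c1cnc(Nc2ccc(C)nc2)c(Cl)c1` gives 8.2 nM in a functional assay on HEK293 cells for negative allosteric modulation of metabotropic glutamate receptor 5 (Homo sapiens), read by HTRF and inositol phosphate accumulation; on this read-out lower numbers stand for stronger inhibition and higher numbers for weaker inhibition
compound 2 `CCC[C@H](NC(=O)c1nccs1)c1cnc(Nc2ccc(C)nc2)c(Cl)c1` gives 978 nM in this assay

Compound 1 has the lowest number of the two measured compounds, so it is the stronger inhibitor in this assay. Among the measured compounds shown here, the only measured step, a 120-fold higher number from compound 1 to compound 2 (2.08 log units; beyond the scatter), is large and comes from the fact that compounds 1 and 2 differ only in the configuration as drawn; the atoms and bonds are the same, only the configuration at the saturated chain carbon is changed.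

Compound 3 `Cc1ccc(Nc2ncc([C@H](NC(=O)c3nccs3)C3CC3)cc2Cl)cn1` keeps the configuration of compound 1 as drawn and changes the chain instead: cyclopropyl in place of propyl on a saturated chain carbon bound to an amide-type nitrogen and an aromatic carbon. For the measured compounds named here, no measured step tests an exchange of this kind, so the measured step gives no direct guide, and it points only to the weight of the stereocentre itself. Since cyclopropyl and propyl are of the same size in heavy atoms, compound 3 is expected to stay close to compound 1, with a step of a 1.2-fold higher number from compound 1 to compound 3 (0.09 log units; within the scatter) that may well fall within the scatter. For compound 3 the estimated value in this assay is 10 nM, in a range from 3 nM to 40 nM.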

Compound 3, half-maximal inhibitory concentration: 9.7 nM
Beside the measured number, compound 3's estimate is 1.0-fold (0.01 log units) above it; the measured number falls inside the stated range.
By their numbers in this assay, from the lowest: compounds 1 and 3 (each within the scatter of the next); then compound 2.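

The earlier pair showed that configuration at this saturated chain carbon matters, but it said nothing about which group the carbon can carry. With the configuration kept as drawn, cyclopropyl in place of propyl gives a 1.2-fold higher number from compound 1 to compound 3 (0.07 log units; within the scatter) in this assay, so in this series a three-membered ring of carbon serves here as well as an open chain with the same number of heavy atoms. Nothing at hand offers a reason why the two groups match so closely.

Still open, as far as these compounds go, is whether the cyclopropyl compound drawn with the opposite configuration would lose as much as the propyl pair does. Also open, from the compounds shown here alone, is how other groups at this carbon would fare, such as a longer chain like pentyl, a tert-butyl group or an amine.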